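Shortening the Chain on the Core of Compound 1

This account rests on a few compounds, and the source may have more. Where it says the series, first, only, none or still open, it means among the compounds named here.

In a functional assay on ileum for inhibition of histamine H1 receptor (Cavia porcellus) (a lower number here means a stronger inhibitor, a higher number a weaker inhibitor), compound 1 `CCCCCCCn1c(N2CCN(C)CC2)nc2ccccc21` gives 150 nM, the higher of the two numbers reported. Compound 3 `CCCOCCn1c(N2CCCN(C)CC2)nc2ccccc21` gives 16 nM, a gap from compound 1 that lies beyond the usual scatter of this kind of measurement. For compound 2 `CCOCCn1c(N2CCN(C(c3ccccc3)c3ccccc3)CC2)nc2ccccc21` the reading is only a limit of the assay, > 3000 nM. The unmeasured compound 4 `CCCC(C)n1c(N2CCN(C)CC2)nc2ccccc21` differs from compound 1 by 1-methylbutyl in place of heptyl on an aromatic nitrogen. Among the measured compounds shown here, no measured pair differs in one place only, so the size of such a step cannot be read from neighbours; the account therefore expects a step from compound 1 to compound 4 of a 1.3-fold higher number from compound 1 to compound 4 (0.12 log units; within the scatter), none beyond the scatter. Compound 4 is estimated at 200 nM, within 50 nM to 800 nM.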

Compound 4, half-maximal inhibitory concentration: 1400 nM
For compound 4 the middle estimate is 7.0-fold (0.85 log units) below the measured one; measured number outside the range, above it.
By their numbers in this assay, from the lowest: compound 3; then compound 1; then compound 4. At a limit, above all of these: compound 2.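

At this aromatic nitrogen, the change from heptyl to 1-methylbutyl is far from neutral: in this assay it brings a 9.3-fold higher number from compound 1 to compound 4 (0.97 log units; beyond the scatter), a step beyond the scatter. Among the compounds shown here, this is the first pair differing in one place only, so it is the first direct sign that the group here affects inhibition on the core of compound 1. Nothing shown accounts for the size of this step. The change both shortens and branches the chain, so the two cannot be separated. Going by these compounds, an unbranched pentyl chain, or an ether chain with the 4-methylpiperazin-1-yl group kept, remains open.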